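Swapping the ring on the sulfonamide nitrogen

The compounds below may be only part of what the source reports. "The series", "measured", "known", "first", "only" and "open" are said of these compounds alone.

Two measured compounds share one core and differ only in what sits on the sulfonamide nitrogen. Compound 1 `NS(=O)(=O)c1ccc(N/C=C\C(=O)c2cc3ccccc3oc2=O)cc1` carries a hydrogen there; in a functional assay on T47D cells (Homo sapiens) for cytotoxicity, read by sulforhodamine B assay, with a stated time of 48 h (on this read-out lower numbers stand for stronger inhibition and higher numbers for weaker inhibition), compound 1 gives 109000 nM. Compound 2 `Cc1nnc(NS(=O)(=O)c2ccc(N/C=C\C(=O)c3cc4ccccc4oc3=O)cc2)s1` carries a 5-methyl-1,3,4-thiadiazol-2-yl group in that place, and in this assay compound 2 gives 94000 nM. That is the lower of the two numbers, but the move a 1.2-fold lower number from compound 1 to compound 2 (0.06 log units; within the scatter) stays within the scatter, so the two compounds cannot be told apart on these figures. Compound 3 `O=C(/C=C\Nc1ccc(S(=O)(=O)Nc2ccccn2)cc1)c1cc2ccccc2oc1=O` is not yet measured; it differs from compound 2 by pyridin-2-yl in place of 5-methyl-1,3,4-thiadiazol-2-yl on a sulfonamide nitrogen. Among the compounds with values here, only one measured step bears on this change: attaching a ring to that nitrogen shifted the number by a 1.2-fold lower number from compound 1 to compound 2 (0.06 log units; within the scatter), a change too small to read. Because that step a 1.2-fold lower number from compound 1 to compound 2 (0.06 log units; within the scatter) was so small, exchanging one ring for another at the same nitrogen is expected to give no step beyond the scatter, and compound 3 is estimated at 100000 nM, between 40000 nM and 250000 nM, which means an expected step of a 1.1-fold higher number from compound 2 to compound 3 (0.03 log units; within the scatter).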

Compound 3, half-maximal inhibitory concentration: 37600 nM
Beside the measured number, compound 3's estimate is 2.7-fold (0.42 log units) above it, and the stated range ends above it.
By their numbers in this assay, from the lowest: compound 3; then compounds 2 and 1 (each within the scatter of the next).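

The identity of the ring on the sulfonamide nitrogen turns out to matter in this assay: pyridin-2-yl in place of 5-methyl-1,3,4-thiadiazol-2-yl gives a 2.5-fold lower number from compound 2 to compound 3 (0.40 log units; beyond the scatter), a modest but readable step, so the earlier unreadable step from hydrogen to the 5-methyl-1,3,4-thiadiazol-2-yl ring does not hold for every ring at this nitrogen. Measured against the plain hydrogen, pyridin-2-yl gives a 2.9-fold lower number from compound 1 to compound 3 (0.46 log units; beyond the scatter), so attaching a ring here can move the number beyond the scatter, although compound 2 shows that this does not happen with every ring. The two rings have the same number of heavy atoms but differ in ring size and hetero atoms, and nothing available explains why the step occurs.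

It remains open which difference between the two rings accounts for the step, a question that the 1,3,4-thiadiazol-2-yl ring without its methyl group or a pyrimidin-2-yl ring could help to settle. From the compounds shown here alone, it is also open whether a group without a ring, such as an acetyl group or a short alkyl chain, would shift the number at this nitrogen.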